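The source may hold more compounds than are shown below. What is called first, only, known or untested is meant among the compounds shown, and "the series" means these compounds.

Measured so far:
- compound 1 `COc1cc(-c2c(C#N)c(-c3ccco3)nc3c2c(-c2ccccc2)nn3-c2ccccc2)ccc1O` gives 36500 nM in a functional assay on CCRF-CEM cells (Homo sapiens) for antiproliferative activity, read by resazurin assay, with a stated time of 72 h; a higher number here means a weaker inhibitor, a lower number a stronger inhibitor
- compound 2 `Cc1ccc(-c2nc3c(c(-c4ccccc4)nn3-c3ccccc3)c(-c3ccc(O)cc3)c2C#N)cc1` gives 13400 nM in this assay

Compound 2 holds the lower of the two numbers recorded in this assay; its nearest neighbour is compound 1, whose number sits higher by a margin that falls beyond the usual scatter. Among the compounds with values here, no pair differing in a single place has been measured, so no single step has been quantified yet.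

Compound 3 `N#Cc1c(-c2ccccc2)nc2c(c(-c3ccccc3)nn2-c2ccccc2)c1-c1ccc(O)cc1` is the next member to be tested. It differs from compound 2 by hydrogen in place of methyl on an aromatic carbon, which is hydrogen in place of methyl on an aromatic carbon; read one bond further out, a 4-methylphenyl group becomes a phenyl group. Within the data shown here, with no measured step of this kind to lean on, the expectation in this assay is a small step at most, in either direction, likely not beyond the scatter, with a slight lean toward a higher number.

For compound 3 the estimate in this assay is 18000 nM, within a range from 6000 nM to 50000 nM. The step from compound 2 that this estimate implies, a 1.3-fold higher number from compound 2 to compound 3 (0.13 log units; within the scatter), is expected to stay small.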

Compound 3, half-maximal inhibitory concentration: 33400 nM
Estimate against measurement, compound 3: 1.9-fold (0.27 log units) below, and the stated range covers the measured number.
By their numbers in this assay, from the lowest: compound 2; then compounds 3 and 1 (each within the scatter of the next).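

In this assay, the series now has its first single-place comparison: going from the 4-methylphenyl group to a phenyl group gives a 2.5-fold higher number from compound 2 to compound 3 (0.40 log units; beyond the scatter) and so moves the number upward. The methyl on this aromatic carbon, para to a large group, is therefore not neutral here, although the change of one carbon yields only a modest step and leaves both compounds with weak numbers in this assay. No available evidence accounts for the step, which stands for now as an observation. 

On these data alone, it remains open whether the direction of this step would carry over to other groups in the same place, such as an ethyl group, a chlorine atom or an amine, and whether any of them would give a lower number than the methyl. Compound 1 differs from compound 2 and compound 3 in more than one place, so its number cannot yet be assigned to any single group.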